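The compounds below may be only part of what the source reports. "The series", "measured", "known", "first", "only" and "open" are said of these compounds alone.

Compound 1 `CCCCc1ccc(CN(C(C)C)S(C)(=O)=O)c(=O)n1Cc1ccc(-c2ccccc2-c2nn[nH]n2)cc1` gives 82.7%; compound 2 `CCCCc1ccc(CN(Cc2ccccc2)S(=O)(=O)c2ccccc2)c(=O)n1Cc1ccc(-c2ccccc2-c2nn[nH]n2)cc1` gives 75.7%; compound 3 `CCCCc1ccc(CN(C)S(=O)(=O)c2ccccc2)c(=O)n1Cc1ccc(-c2ccccc2-c2nn[nH]n2)cc1` gives 68.7%.

All three were tested in a functional assay on the whole organism (artery) for inhibition, with Rattus norvegicus as the target, at a dose of 3 mg/kg by the intraduodenal route; on this read-out higher numbers stand for more inhibition at the one dose given (going by the name of the read-out) and lower numbers for less inhibition. Compound 3 has the lowest of the three numbers, but only one gap is meaningful: the step of a number 14 percentage points lower from compound 1 to compound 3 (beyond the scatter) is beyond the scatter, whereas the step of a number 7 percentage points lower from compound 2 to compound 3 (within the scatter) is within it, so compound 3 and compound 2 cannot be told apart. Compound 4 `CCCCc1ccc(CN(C)S(C)(=O)=O)c(=O)n1Cc1ccc(-c2ccccc2-c2nn[nH]n2)cc1` differs from compound 3 in one place: methyl in place of phenyl on a sulfonyl sulfur. Going by the values given here, no measured step isolates this change. The step from compound 1 to compound 3 contains it, yet that step also exchanges methyl(phenylsulfonyl)amino for isopropyl(methylsulfonyl)amino, so only part of its size can be credited here. A small rise is therefore expected for compound 4, a number 7.3 percentage points higher from compound 3 to compound 4 (within the scatter), near the edge of the scatter. Compound 4 is estimated at 76%, between 60% and 90%.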

Compound 4, a percentage reported as inhibition, in the whole organism at one dose (the size of the read-out at that dose, not a potency): 83.4%
Estimate against measurement, compound 4: 7.4 percentage points below; measured number inside the range.
By their numbers in this assay, from the lowest: compounds 3, 2, 1 and 4 (each within the scatter of the next, the first and the last beyond it).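

Phenyl gives way to methyl on the sulfonyl sulfur, with the methyl on the sulfonamide nitrogen unchanged, in a number 14.7 percentage points higher from compound 3 to compound 4 (beyond the scatter), so this one exchange is enough to move the read-out. Methyl in place of isopropyl on the sulfonamide nitrogen gives a number 0.7 percentage points higher from compound 1 to compound 4 (within the scatter), so with methylsulfonyl present, these two nitrogen groups cannot be told apart. Nothing available explains why the sulfonyl change matters. Still open, as far as these compounds go, is how an ethyl, a longer chain or a trifluoromethyl on the sulfonyl sulfur would compare with methyl. A single dose also leaves the relative potency of these compounds open.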